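The source may hold more compounds than are shown below. What is called first, only, known or untested is meant among the compounds shown, and "the series" means these compounds.

In a functional assay on MGC-803 cells (Homo sapiens) for cytotoxicity, read by MTT assay, with a stated time of 72 h (a higher number here means a weaker inhibitor, a lower number a stronger inhibitor), compound 3 `O=[N+]([O-])c1ccc(Nc2nc(SCc3ccc(C(F)(F)F)cc3)nc3ccccc23)cc1` gives 8170 nM and sits at the low end of the two numbers reported, with compound 2 `FC(F)(F)c1ccc(CSc2nc(Nc3cccc(Cl)c3)c3ccccc3n2)cc1` giving 14600 nM and the gap a 1.8-fold lower number from compound 2 to compound 3 (0.25 log units; within the scatter) lying within the scatter. Compound 1 `FC(F)(F)c1ccc(CSc2nc(Nc3ccccc3Cl)c3ccccc3n2)cc1` reports only a limit, > 50000 nM. The steps of an at least 3.4-fold lower number from compound 1 to compound 2 (0.53 log units; beyond the scatter) and an at least 6.1-fold lower number from compound 1 to compound 3 (0.78 log units; beyond the scatter) both lowered the number. Compound 4 `COc1ccc(Nc2nc(SCc3ccc(C(F)(F)F)cc3)nc3ccccc23)c(OC)c1` differs from compound 3 by 2,4-dimethoxyphenyl in place of 4-nitrophenyl on a nitrogen on an aromatic ring. The measured steps concern only chlorophenyl and nitrophenyl groups on that nitrogen, so they bear loosely on a dimethoxyphenyl group and give no clear direction. Compound 4 is therefore expected to remain close to compound 3, a 1.2-fold higher number from compound 3 to compound 4 (0.09 log units; within the scatter), inside the scatter. The estimated value of compound 4 in this assay is 10000 nM, between 3000 nM and 40000 nM.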

Compound 4, half-maximal inhibitory concentration: > 50000 nM
Compound 4 ended at the assay's limit; the forecaster's own chance of this, stated with the estimate: 15%; middle value at least 5.0-fold (0.69 log units) from the limit.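

Exchanging the group on this nitrogen can also raise the number: 2,4-dimethoxyphenyl in place of 4-nitrophenyl gives an at least 6.1-fold higher number from compound 3 to compound 4 (0.78 log units; beyond the scatter) and in place of 3-chlorophenyl gives an at least 3.4-fold higher number from compound 2 to compound 4 (0.53 log units; beyond the scatter) in this assay. The value of compound 4 is a limit, so reaching the limit is no longer tied to the 2-chlorophenyl group of compound 1. The step between compound 1 and compound 4 cannot be read, because both stand at the limit: the limit of > 50000 nM in this assay, at which 2 of the 4 values shown sit. On these data alone, whether a single methoxy group would reach this limit stays open, as does how a phenyl ring carrying an amine or a carboxylic acid would behave on this nitrogen.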